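A Methyl on the Thiazole of Compound 2

The source may report more compounds than this note shows. Statements on the series, on what has been measured and on what is new or still open speak of the compounds shown alone.

Compound 2 `CCCOc1cc(C)c2c(c1C)C[C@H]([C@@H](C)C(=O)Nc1nccs1)CC2` gives 1000 nM in an assay on isolated protein for inhibition of Polyunsaturated fatty acid 5-lipoxygenase (Homo sapiens) (a lower number here means a stronger inhibitor, a higher number a weaker inhibitor), the lowest of the two numbers shown. Its partner, compound 1 `CCCOc1cc(C)c2c(c1C)C[C@H]([C@@H](C)C(=O)Nc1ccccn1)CC2`, gives 6000 nM in this assay; the step of a 6.0-fold lower number from compound 1 to compound 2 (0.78 log units; beyond the scatter) shows that swapping the ring on the amide nitrogen makes a clear difference. Compound 3 `CCCOc1cc(C)c2c(c1C)C[C@H]([C@@H](C)C(=O)Nc1ncc(C)s1)CC2` differs from compound 2 by methyl in place of hydrogen on an aromatic carbon, a methyl in place of hydrogen on an aromatic carbon. No measured step tests such a methyl, so the one step shown does not bear on it directly. Compound 3 is therefore expected near 800 nM, between 300 nM and 2500 nM, a step of a 1.3-fold lower number from compound 2 to compound 3 (0.10 log units; within the scatter) that stays within the scatter.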

Compound 3, half-maximal inhibitory concentration: 800 nM
Estimate against measurement, compound 3: no gap at the digits printed; the measured number falls inside the stated range.
By their numbers in this assay, from the lowest: compounds 3 and 2 (each within the scatter of the next); then compound 1.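

In this assay, a methyl on the aromatic carbon next to the ring sulfur gives a 1.3-fold lower number from compound 2 to compound 3 (0.10 log units; within the scatter), so this position accepts the group without a readable change. The advantage of the thiazole over the pyridin-2-yl group also remains with the methyl in place, at a 7.5-fold lower number from compound 1 to compound 3 (0.88 log units; beyond the scatter). No measurement shown explains either step. Still open, on these data alone, is whether a longer chain such as ethyl, or an amine, on this same carbon would also stay within the scatter of compound 2.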